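A Methoxy Added to a Single Measured Compound

The source may report more compounds than this note shows. Statements on the series, on what has been measured and on what is new or still open speak of the compounds shown alone.

In a functional assay on U-937 cells (Homo sapiens) for inhibition, read by MTT assay, with a stated time of 48 h (on this read-out higher numbers stand for weaker inhibition and lower numbers for stronger inhibition), compound 1 (`O=S(=O)(c1ccccc1)c1c(OCCCCCCO)no[n+]1[O-]`) stands as "not determined" (no result reported), so it offers no number for comparison. Compound 2 (`O=C(NO)c1ccc(Oc2no[n+]([O-])c2S(=O)(=O)c2ccccc2)cc1`) gives 4730 nM in this assay. Going by the values given here, this is the only number available, so it cannot yet be called strong or weak relative to any other compound here.

Compound 3 (`COc1cc(C(=O)NO)ccc1Oc1no[n+]([O-])c1S(=O)(=O)c1ccccc1`) is compound 2 with one small change: methoxy in place of hydrogen on an aromatic carbon. Put simply, a methoxy takes the place of hydrogen on an aromatic carbon of the six-membered ring that carries the hydroxycarbamoyl group. The new group sits ortho to a large group and meta to the hydroxycarbamoyl group.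

Among the compounds with values here, no pair of measured compounds shows what such a swap does, so neither direction can be favoured. The expectation rests on compound 2 and its 4730 nM alone, and no step beyond the usual scatter is expected. The estimate amounts to a 1.2-fold lower number from compound 2 to compound 3 (0.07 log units; within the scatter). For compound 3 the expected value is 4000 nM, with an estimated range of 1200 nM to 13000 nM.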

Compound 3, half-maximal inhibitory concentration: 3640 nM
Estimate against measurement, compound 3: 1.1-fold (0.04 log units) above; measured number inside the range.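

In this assay, putting methoxy in place of hydrogen gives a 1.3-fold lower number from compound 2 to compound 3 (0.11 log units; within the scatter), so the two compounds cannot be told apart on this read-out. Going by these compounds alone, this is the only measured pair here that differs in one place, and it gives a first look at this aromatic carbon, ortho to a large group and meta to a hydroxycarbamoyl group: this position can carry a methoxy with the number staying within the usual scatter of repeated measurements. No measurement shown here bears on why the swap leaves the number in that range, so the step stands as an observation only.

From the compounds shown here alone, one methoxy at one position says little about other groups, so it remains open whether an amine, a carboxylic acid or a longer chain such as butoxy at this carbon would also stay within the scatter or would move the number clearly. Also open, going by these compounds, is whether methoxy on another carbon of the same ring would behave alike, and compound 1, having no number, adds nothing to either question.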